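Moving a hydroxyl around one phenyl ring

This account rests on a few compounds, and the source may have more. Where it says the series, first, only, none or still open, it means among the compounds named here.

Measured so far:
- compound 1, `Oc1ccc(-c2cc(-c3ccco3)cc(-c3cccc(O)c3)n2)cc1`: 2070 nM
- compound 2, `Oc1ccc(-c2cc(-c3ccoc3)cc(-c3cccc(O)c3)n2)cc1`: 2700 nM
- compound 3, `Oc1ccc(-c2cc(-c3cccnc3)cc(-c3ccccc3O)n2)cc1`: > 50000 nM

All three share a core carrying a 4-hydroxyphenyl group, a hydroxyphenyl group and a five- or six-membered aromatic ring. In a functional assay on DU-145 cells (Homo sapiens) for cytotoxicity, read by CCK-8 assay (a lower number here means a stronger inhibitor, a higher number a weaker inhibitor), compound 1 gives 2070 nM. In this assay compound 2 gives 2700 nM, and the step of a 1.3-fold higher number from compound 1 to compound 2 (0.12 log units; within the scatter) shows that swapping the furan position changes little. For compound 3 this assay reports only a limit, > 50000 nM, so its true potency is not known, only that it lies at or beyond the limit (the limit of > 50000 nM in this assay, at which 1 of the 3 values shown sits).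

Compound 4, `Oc1ccc(-c2cc(-c3cccnc3)cc(-c3cccc(O)c3)n2)cc1`, differs from compound 3 in one place: 3-hydroxyphenyl in place of 2-hydroxyphenyl on an aromatic carbon. Among the compounds with values here, no measured step here involves this change, since the only measured step, a 1.3-fold higher number from compound 1 to compound 2 (0.12 log units; within the scatter), concerns the furan ring. Compounds 1 and 2, which carry a 3-hydroxyphenyl group, both give numbers rather than limits. Compound 4 is therefore expected to land between those numbers and the limit of compound 3, about 8000 nM, with a range of 2000 nM to 50000 nM. This estimate corresponds to the step of an at least 6.2-fold lower number from compound 3 to compound 4 (0.79 log units; beyond the scatter), expected but uncertain.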

Compound 4, half-maximal inhibitory concentration: 6390 nM
For compound 4 the middle estimate is 1.3-fold (0.10 log units) above the measured one; measured number inside the range.
By their numbers in this assay, from the lowest: compounds 1 and 2 (each within the scatter of the next); then compound 4. At a limit, above all of these: compound 3.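

Moving the hydroxyl from 2-hydroxyphenyl to 3-hydroxyphenyl at this position, with pyridin-3-yl kept, gives an at least 7.8-fold lower number from compound 3 to compound 4 (0.89 log units; beyond the scatter), so in this assay this single change turns a limit into a measured number. Compound 3 stands at a limit, not at a number: the limit of > 50000 nM in this assay, at which 1 of the 4 values shown sits. The earlier furan swap moved little, whereas the choice between a furan and pyridin-3-yl does register, with a 2.4-fold higher number from compound 2 to compound 4 (0.37 log units; beyond the scatter) for the change from furan-3-yl and a 3.1-fold higher number from compound 1 to compound 4 (0.49 log units; beyond the scatter) for the change from furan-2-yl.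

Within the data shown here, the hydroxyl move is seen only with pyridin-3-yl, so whether it matters as much with either furan remains open. Also open, on these data alone, is whether a hydroxyl is needed on this ring at all, or whether a methoxy group or an amine in its place would serve as well.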